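A few compounds are considered here, and "the series" means these few. Any claim that something is new, unique, unknown or untested is made for them only; others in the source may bear on it.

Of the compounds shown here, three built on a shared core have been measured in a functional assay on NCI-H460 cells (Homo sapiens) for cytotoxicity, read by MTT assay, with a stated time of 72 h; on this read-out higher numbers stand for weaker inhibition and lower numbers for stronger inhibition. Compound 2 `CN(C)CCn1cnnc1-c1cc(Oc2ccc(NC(=O)N/N=C/c3cccc(Cl)c3Cl)cc2F)ccn1` gives 72 nM, the lowest number among the three. Compound 1 `CN(C)CCn1cnnc1-c1cc(Oc2ccc(NC(=O)N/N=C/c3cc(C(C)(C)C)cc(C(C)(C)C)c3O)cc2F)ccn1` gives 590 nM and stands nearest to compound 2, though still beyond the scatter. Compound 3 `Cn1cnnc1-c1cc(Oc2ccc(NC(=O)N/N=C/c3ccccc3)cc2F)ccn1` gives 15700 nM and stands furthest from compound 2, far beyond the scatter; it also differs from compound 2 in more than one place, so its value speaks only for itself.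

Compound 4 `Cc1cc(/C=N/NC(=O)Nc2ccc(Oc3ccnc(-c4nncn4CCN(C)C)c3)c(F)c2)cc(C)c1O` has not yet been measured in this assay. It differs from compound 2 in one place: 4-hydroxy-3,5-dimethylphenyl in place of 2,3-dichlorophenyl on a carbon with a double bond to nitrogen. The entering group brings one hydrogen-bond donor and one hydrogen-bond acceptor where the leaving group had none. Among the measured compounds shown here, no measured pair separates this change on its own. Compound 1 also carries a hydroxy group on the ring at this position and gives 590 nM, a weaker result than compound 2, which is the only hint available. A step toward weaker inhibition, beyond the scatter, is therefore expected in this assay. Compound 4 is expected to give about 350 nM, within a range from 90 nM to 1500 nM. The expected step is a 4.9-fold higher number from compound 2 to compound 4 (0.69 log units; beyond the scatter).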

Compound 4, half-maximal inhibitory concentration: 2010 nM
Beside the measured number, compound 4's estimate is 5.7-fold (0.76 log units) below it; the measured number lies above the stated range.
By their numbers in this assay, from the lowest: compound 2; then compound 1; then compound 4; then compound 3.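

In this assay, among the compounds shown here, the pair of compound 2 and compound 4 isolates a change at this position for the first time: 4-hydroxy-3,5-dimethylphenyl in place of 2,3-dichlorophenyl on a carbon with a double bond to nitrogen gives a 28-fold higher number from compound 2 to compound 4 (1.45 log units; beyond the scatter). The six-membered aromatic ring of carbon stays in both compounds, so this large step goes with what the ring carries: the chlorine atoms leave, and hydroxy and methyl groups enter. This shows that the read-out is sensitive to the ring's substituents at this position, while no measurement offered here explains the size of the step.

The change replaces all of these substituents at once, so the compounds shown leave open whether the step follows the arrival of the hydroxy group, the arrival of the methyl groups or the departure of the chlorine atoms. A dimethylphenyl group without the hydroxy, a methoxy group in place of the hydroxy, or a monochlorophenyl group at the same place would help to separate these contributions.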